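Methyl to methoxy on the pendant aryl across two cores

The source may hold more compounds than are shown below. What is called first, only, known or untested is meant among the compounds shown, and "the series" means these compounds.

The series rests on two cores. Compound 1 `Cc1ccc(-c2cc3cc(C#N)c(C#N)cc3n2O)cc1` and compound 2 `COc1ccc(-c2cc3cc(C#N)c(C#N)cc3n2O)cc1` share one; compound 3 `COn1c(-c2ccc(C)cc2)c(C=O)c2cc(C#N)c(C#N)cc21` and the unmeasured compound 4 `COc1ccc(-c2c(C=O)c3cc(C#N)c(C#N)cc3n2OC)cc1` share another, carrying an additional carbonyl and a methoxy on the ring nitrogen. The difference between the two cores is not broken down here.

In an assay on isolated protein for inhibition of Amine oxidase [flavin-containing] B (Homo sapiens), read by fluorescence and spectrophotometry, with a stated time of 20 min (on this read-out lower numbers stand for stronger inhibition and higher numbers for weaker inhibition), compound 1 gives 821 nM. Compound 2 differs from compound 1 by methoxy in place of methyl on an aromatic carbon, and in this assay compound 2 gives 1790 nM. Among the compounds with values here, the step of a 2.2-fold higher number from compound 1 to compound 2 (0.34 log units; beyond the scatter) is the one measured instance of this change. Compound 3 is the weakest of the three measured compounds: in this assay compound 3 gives 74800 nM, far beyond the scatter from both compound 1 and compound 2.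

Compound 4 differs from compound 3 by methoxy in place of methyl on an aromatic carbon, which, cut one bond further out, reads 4-methylphenyl to 4-methoxyphenyl. The place is the same as before, on an aromatic carbon of a six-membered aromatic ring of carbon only, para to a large group, but on a different core, so this is the same kind of change rather than the same change. Within the data shown here, the single precedent rests on one pair only, and the second core already sits far weaker.

The step expected is a 2.1-fold higher number from compound 3 to compound 4 (0.33 log units; beyond the scatter), taken from a 2.2-fold higher number from compound 1 to compound 2 (0.34 log units; beyond the scatter) with a wide margin for the changed core. Compound 4 is therefore estimated at 160000 nM in this assay, in a range from 60000 nM to 400000 nM, with a fair chance that the read-out returns only a limit.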

Compound 4, half-maximal inhibitory concentration: > 100000 nM
Compound 4: only a limit was reported; the forecaster's own chance of this, stated with the estimate: 30%; the middle value lies beyond the limit too.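

In this assay compound 4 gives > 100000 nM, which is a limit of the assay and not a number. On the second core, methoxy in place of methyl can therefore be read only as a floor, an at least 1.3-fold higher number from compound 3 to compound 4 (0.12 log units; that floor lies within the scatter), which fits a step of the size seen on the first core but does not by itself establish one beyond the scatter. The data show no reversal of the change on the second core, but they do not show that its size carries over from one core to the other: the same change on two cores in this assay, a 2.2-fold higher number (0.34 log units; beyond the scatter) from compound 1 to compound 2 and an at least 1.3-fold higher number (0.12 log units; that floor lies within the scatter) from compound 3 to compound 4; the limit leaves it open whether they differ

Still open, from the compounds shown here alone, is how the same place on either core responds to groups other than methyl and methoxy, such as an amine, a carboxylic acid or a longer chain. Also open, going by these compounds, is how the difference between the two cores divides between the additional carbonyl and the methoxy on the ring nitrogen, and whether a change on the pendant aryl of the second core can bring a value back within the measurable range of this assay.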